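Tolerance of a hydrazone series on human T-cell line

The compounds below may be only part of what the source reports. "The series", "measured", "known", "first", "only" and "open" are said of these compounds alone.

Compound 1 `C/C(=N\NC(=O)COc1cccc2ccccc12)c1ccc(C#N)cc1Br` is a naphthyloxyacetyl hydrazone bearing a 2-bromo-4-cyanophenyl group. In an ADME assay on MT4 cells (Homo sapiens) for cytotoxicity, read by MTT assay, with a stated time of 4 days (a higher number here means that more compound is tolerated, a lower number that less compound is tolerated), compound 1 gives 12.1 ug/mL, the lowest of the two numbers seen so far. Compound 2 `O=C(COc1cccc2ccccc12)N/N=C/c1ccc([N+](=O)[O-])cc1` gives 87.9 ug/mL in this assay, a gap beyond the usual scatter. Compound 3 `C/C(=N\NC(=O)COc1cccc2ccccc12)c1ccc(Cl)cc1` differs from compound 1 in one place: 4-chlorophenyl in place of 2-bromo-4-cyanophenyl on a carbon with a double bond to nitrogen. Going by the values given here, no such step has yet been measured, so only an expectation can be offered: a modest rise in the tolerated concentration, a 1.7-fold higher number from compound 1 to compound 3 (0.22 log units; within the scatter), is expected. Compound 3 is therefore estimated at 20 ug/mL, within a range from 6 ug/mL to 70 ug/mL.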

Compound 3, half-maximal cytotoxic concentration: 4.07 ug/mL
Beside the measured number, compound 3's estimate is 4.9-fold (0.69 log units) above it; the whole stated range lies above it.
By their numbers in this assay, from the lowest: compound 3; then compound 1; then compound 2.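

In this assay, going by these compounds alone, the replacement of 2-bromo-4-cyanophenyl by 4-chlorophenyl on the carbon with a double bond to nitrogen gives a 3.0-fold lower number from compound 1 to compound 3 (0.47 log units; beyond the scatter) and provides the first one-place comparison. It shows that the aryl group at this place can change the tolerated concentration beyond the usual scatter, with the 2-bromo-4-cyanophenyl compound the better tolerated of this pair. No measured evidence here explains the change.

The compounds shown leave open how the bromine, the nitrile and the chlorine each contribute, as these groups change together in this step. They also leave open how a phenyl ring carrying an amine or a carboxylic acid at this place would fare.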